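Halogen rearrangement on the sulfonamide aryl ring

The compounds below may be only part of what the source reports. "The series", "measured", "known", "first", "only" and "open" are said of these compounds alone.

In an assay on isolated protein for binding affinity to 5-hydroxytryptamine receptor 6 (Homo sapiens) (a lower number here means a stronger inhibitor, a higher number a weaker inhibitor), compound 1 `COc1ccc(S(=O)(=O)Nc2ccc(Cl)c(Cl)c2)cc1N1CCNCC1` gives 2.51 nM, while compound 2 `COc1ccc(S(=O)(=O)Nc2cc(Cl)c(Cl)cc2Cl)cc1N1CCNCC1` gives 5.01 nM. Among the measured compounds shown here, compound 2 thus holds the higher of the two numbers, its only neighbour being compound 1, with a 2.0-fold higher number from compound 1 to compound 2 (0.30 log units; within the scatter) lying within the scatter. Compound 3 `COc1ccc(S(=O)(=O)Nc2cc(Br)cc(Cl)c2Cl)cc1N1CCNCC1` differs from compound 2 by 5-bromo-2,3-dichlorophenyl in place of 2,4,5-trichlorophenyl on a sulfonamide nitrogen. For the measured compounds named here, only that single step, a chloro for hydrogen, bears on this change, and it stayed within the scatter, so no step beyond the scatter is expected in this assay: a 1.0-fold lower number from compound 2 to compound 3 (0.00 log units; within the scatter). Compound 3 is therefore estimated at 5 nM, within 2 nM to 13 nM.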

Compound 3, inhibition constant: 3.98 nM
Estimate against measurement, compound 3: 1.3-fold (0.10 log units) above, and the stated range covers the measured number.
By their numbers in this assay, from the lowest: compounds 1, 3 and 2 (each within the scatter of the next).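

Replacing 2,4,5-trichlorophenyl with 5-bromo-2,3-dichlorophenyl on a sulfonamide nitrogen brings in a bromine and rearranges the halogens, yet in this assay the result stays within the scatter (a 1.3-fold lower number from compound 2 to compound 3 (0.10 log units; within the scatter)). Replacing 3,4-dichlorophenyl with the same group also stays within the scatter (a 1.6-fold higher number from compound 1 to compound 3 (0.20 log units; within the scatter)), so all three halogen patterns read alike at this position. No evidence is available to explain this. On these data alone, what an amine or a carboxylic acid on this aryl ring would do remains open.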